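Removing the Aminomethyl from the Anilino Ring of Compound 1

The source may report more compounds than this note shows. Statements on the series, on what has been measured and on what is new or still open speak of the compounds shown alone.

Compound 1 `NCc1ccc(NC(=O)N(CCCCO)Cc2ccc(C(=O)NO)cc2)cc1` gives 3420 nM in an assay on HEK293 cells for inhibition of histone deacetylase 5 (Homo sapiens), read by fluorescence, with stated times of 10 min and 30 min (on this read-out lower numbers stand for stronger inhibition and higher numbers for weaker inhibition), the lower of the two numbers measured. Compound 2 `CCCCN(Cc1ccc(C(=O)NO)cc1)C(=O)Nc1ccc(CN)cc1` gives 10100 nM, and the step of a 3.0-fold higher number from compound 1 to compound 2 (0.47 log units; beyond the scatter) concerns a saturated chain carbon rather than the aromatic ring. Compound 3 `O=C(NO)c1ccc(CN(CCCCO)C(=O)Nc2ccccc2)cc1` differs from compound 1 by hydrogen in place of aminomethyl on an aromatic carbon, the 4-(aminomethyl)phenyl becoming phenyl. Going by the values given here, no measured step bears on this ring, so the change for compound 3 is estimated as a 1.5-fold higher number from compound 1 to compound 3 (0.16 log units; within the scatter), a slight weakening that may still fall within the scatter. Compound 3 is therefore expected to give 5000 nM, within 1500 nM to 17000 nM.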

Compound 3, half-maximal inhibitory concentration: 9130 nM
Compound 3: middle estimate off by 1.8-fold (0.26 log units), on the low side; the range from low to high includes it.
By their numbers in this assay, from the lowest: compound 1; then compounds 3 and 2 (each within the scatter of the next).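

In this assay, replacing the aminomethyl with hydrogen gives a 2.7-fold higher number from compound 1 to compound 3 (0.43 log units; beyond the scatter), so this aromatic carbon, para to a large group, is not indifferent to the change. The step is modest, and compound 1, with its 4-(aminomethyl)phenyl, keeps the lower number of the pair. No measurement here accounts for the shift.

The compounds shown leave open whether a carboxylic acid or a longer aminoalkyl chain on this carbon would lower the number further or raise it. They also leave open whether losing the aminomethyl costs the same on compound 2, which lacks the hydroxy.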